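A few compounds are considered here, and "the series" means these few. Any claim that something is new, unique, unknown or untested is made for them only; others in the source may bear on it.

Measured compounds:
Compound 1 `CCN1CCCC(n2cc(S(=O)(=O)c3cccc(F)c3)c3cc(OC)ccc32)C1` gives 50% in a functional assay on HeLa cells for agonist activity at 5-hydroxytryptamine receptor 6 (Homo sapiens), read by cAMP accumulation and immunoassay, with a stated time of 10 min; on this read-out higher numbers stand for larger maximal responses and lower numbers for smaller maximal responses.
Compound 2 `COc1ccc2c(c1)c(S(=O)(=O)c1cccc(F)c1)cn2C1CCCN(C)C1` is reported as "not determined" (no result reported) in this assay.

Compound 2 stands nowhere on the numbers shown: no value for it was reported in this assay, so its own position cannot be placed. Within the data shown here, the only measured anchor is compound 1, which in this assay reaches 50%. Among the measured compounds shown here, compound 1 and compound 2 share the same core and the same sulfonyl group; compound 1 carries an ethyl on the ring nitrogen where compound 2 carries a methyl, but no step between them exists in the data, because compound 2 was not measured.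

Compound 3 `COc1ccc2c(c1)c(S(=O)(=O)c1cccc(F)c1)cn2C1CCCNC1` has yet to be measured in this assay. It differs from compound 2 by hydrogen in place of methyl on an amine nitrogen in a ring.

For the measured compounds named here, with no step between measured compounds, the size of the change from compound 2 to compound 3 in this assay cannot be read from the data; it is expected to be modest, in either direction or none beyond the scatter, the expectation resting only on compound 1 at 50%. Compound 3 is estimated to reach 50%, in the range 20% to 85%.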

Compound 3, largest response reached (Emax), in percent of the reference or control that the assay uses: 75%
The estimate for compound 3 lay 25 percentage points below the measured number, within the range that was stated.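

With compound 3, the amine nitrogen in the ring gains its first readable step in this assay: hydrogen in place of ethyl gives a number 25 percentage points higher from compound 1 to compound 3 (beyond the scatter) and so moves the maximal response by more than the usual scatter. The group on this nitrogen is therefore not neutral for the response in this pair, and the compound with hydrogen there, on an otherwise unchanged core, stands higher than the compound with ethyl. The data shown contain nothing that accounts for this step, which remains an observation about these two compounds.

Compound 2 has no number in this assay, so the steps that link its methyl group to hydrogen or to ethyl cannot be read, and two values cannot show whether the response follows the size of the group across the series. As far as these compounds go, it also remains open how a longer chain such as propyl, a benzyl group or an acetyl group on the same nitrogen would compare with hydrogen and ethyl.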